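A few compounds are considered here, and "the series" means these few. Any claim that something is new, unique, unknown or untested is made for them only; others in the source may bear on it.

Working notes on the series. Compound 1 `O=c1cc(NC2CC2)cc(-c2ccccc2)o1` carries a cyclopropyl group on the nitrogen on the aromatic ring. In a functional assay on KBVIN cells (Homo sapiens) for cytotoxicity, read by MTT assay, with a stated time of 72 h (a lower number here means that less compound is needed, a higher number that more compound is needed for the effect), compound 1 gives only a limit, > 30 uM, and no number. the limit of > 30 uM in this assay, at which 1 of the 3 values shown sits, marks where it sits. Two other members of the series carry an aryl group on that nitrogen. Compound 2 `COc1ccccc1Nc1cc(-c2ccccc2)oc(=O)c1` gives 0.49 uM in this assay. Compound 3 `COc1ccc(Nc2cc(-c3ccco3)oc(=O)c2)cc1` gives 1.46 uM in this assay. For the measured compounds named here, no direct step between any two measured members is available, as each pair differs in more than one place, so the values of compounds 2 and 3 show only that both lie well inside the measured range while compound 1 does not.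

Compound 4 `O=c1cc(NC2CCCCC2)cc(-c2ccccc2)o1` is the next member: cyclohexyl in place of cyclopropyl on a nitrogen on an aromatic ring. Going by the values given here, whether a larger saturated ring on that nitrogen moves the series away from the limit cannot be read from the measured set, the only available comparison being with aryl groups, a change of a different kind. The expected step from compound 1 to compound 4 is an at least 1.2-fold lower number from compound 1 to compound 4 (0.07 log units; that floor lies within the scatter), towards lower concentration but with wide uncertainty. Compound 4 is estimated at 25 uM, with a likely range from 5 uM to 60 uM. A reported limit rather than a number remains a real possibility for compound 4.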

Compound 4, concentration for half-maximal effect: 9.15 uM
Compound 4: middle estimate off by 2.7-fold (0.44 log units), on the high side; measured number inside the range.
By their numbers in this assay, from the lowest: compound 2; then compound 3; then compound 4. At a limit, above all of these: compound 1.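

Working from this assay, the series now has its first comparison in one place, on a nitrogen on an aromatic ring: cyclohexyl in place of cyclopropyl gives an at least 3.2-fold lower number from compound 1 to compound 4 (0.51 log units; beyond the scatter). An aryl group on this nitrogen is therefore not required for a measured number in the series, since compound 4 reaches one with a saturated carbon ring, although this rests on a single change between two compounds. From the compounds shown here alone, compound 1 stands only as a limit and not as a number, so the step has a floor and its full size stays unknown: the limit of > 30 uM in this assay, at which 1 of the 4 values shown sits.

For the compounds shown here, with only two saturated rings at this position, the data cannot separate an effect of ring size from a feature particular to cyclopropyl or cyclohexyl, and they give no reason for the step. Cyclobutyl or cyclopentyl on the same nitrogen would show whether the values change gradually with ring size, while an open hexyl chain or a piperidine ring carrying a basic amine would show whether a carbon ring is needed at all.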